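Notes on removing trifluoromethyl from compound 2

The compounds below may be only part of what the source reports. "The series", "measured", "known", "first", "only" and "open" are said of these compounds alone.

Measured in a functional assay on the whole organism (strain Swiss) with Mus musculus as the target, in the maximal electroshock model, with a stated time of 1 h, at a dose of 300 mg/kg by the intraperitoneal route; on this read-out higher numbers stand for a stronger effect at the one dose given and lower numbers for a weaker effect:
compound 1 `CC(C(=O)N1CCN(c2ccc(C(F)(F)F)cc2)CC1)N1C(=O)CCC1=O` gives 0%;
compound 2 `CCC(C(=O)N1CCN(c2ccc(C(F)(F)F)cc2)CC1)N1C(=O)CCC1=O` gives 0%;
compound 3 `CC(C(=O)N1CCN(c2cccc(Cl)c2)CC1)N1C(=O)CCC1=O` gives 75%.

Compound 2 stands level with compound 1, the two together at the lowest numbers, while compound 3 lies higher by a margin beyond the scatter. Going by the values given here, the only step measured, no change at the digits printed from compound 1 to compound 2 (within the scatter), concerns the saturated chain and not the aromatic ring, so it does not bear on the change to compound 4. Compound 4 `CCC(C(=O)N1CCN(c2ccccc2)CC1)N1C(=O)CCC1=O` differs from compound 2 by hydrogen in place of trifluoromethyl on an aromatic carbon. Among the compounds with values here, no measured pair covers this change; compound 3 only shows that another substitution of the ring in the shared core can give a high number. The expected step of a number 30 percentage points higher from compound 2 to compound 4 (beyond the scatter) is therefore uncertain, leaning upward. Compound 4 is estimated at 30%, with a range from 0% to 75%.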

Compound 4, a percentage reported as activity, at one dose (the size of the read-out at that dose, not a potency): 75%
Estimate against measurement, compound 4: 45 percentage points below; the measured number falls inside the stated range.
By their numbers in this assay, from the lowest: compounds 1 and 2 (each within the scatter of the next); then compounds 3 and 4 (each within the scatter of the next).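

Hydrogen in place of trifluoromethyl on an aromatic carbon, para to a large group, gives a number 75 percentage points higher from compound 2 to compound 4 (beyond the scatter) in this assay. Going by these compounds alone, this is the first measured change at this position, and it shows that the ring substituent can decide the read-out at the one dose given, which the earlier step on the saturated chain could not show. Nothing available explains the size of this step.

From the compounds shown here alone, whether a methoxy group or a single fluorine atom at this position would stay near compound 4 remains open. So does whether the same change on the core of compound 1 would give a similar step.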